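A few compounds are considered here, and "the series" means these few. Any claim that something is new, unique, unknown or untested is made for them only; others in the source may bear on it.

The measured compounds:
Compound 1 `O=C(/C=C/c1coc2cc(O)ccc2c1=O)NCc1ccc(F)cc1` gives > 100000 nM in a functional assay (QGY7701 cells, Homo sapiens) for inhibition, read by MTT assay, with a stated time of 48 h (a lower number here means a stronger inhibitor, a higher number a weaker inhibitor), which is a limit of the assay rather than a number.
Compound 2 `COc1ccc2c(=O)c(/C=C/C(=O)Nc3ccc(Cl)cc3)coc2c1` gives > 100000 nM in this assay, again a limit.
Compound 3 `COc1ccc(CNC(=O)/C=C/c2coc3cc(O)ccc3c2=O)cc1` gives 10000 nM in this assay.

Compound 2 thus sits at the limit of > 100000 nM in this assay, at which 2 of the 3 values shown sit. Its value is a limit, so where it truly stands is not known.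

Compound 4 `COc1ccc2c(=O)c(/C=C/C(=O)NCc3ccccc3F)coc2c1` has not yet been measured. It differs from compound 2 in one place: 2-fluorobenzyl in place of 4-chlorophenyl on an amide-type nitrogen. Among the compounds with values here, the only measured step, an at least 10-fold lower number from compound 1 to compound 3 (1.00 log units; beyond the scatter), concerns a group on a benzyl ring and leaves the amide-type nitrogen as it is, so it does not bear directly on the change from an aryl to a benzyl group there. Compound 1, which carries a fluorinated benzyl group on a different core, sits at the limit, while compound 3, with a methoxy group on its benzyl ring, gives a number. With so little to go on, compound 4 is expected to remain a weak inhibitor, with a real chance that it too sits at the limit; the step of an at least 1.6-fold lower number from compound 2 to compound 4 (0.22 log units; that floor lies within the scatter) is estimated to be small. Compound 4 is estimated at 60000 nM, within 10000 nM to 150000 nM.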

Compound 4, half-maximal inhibitory concentration: 34000 nM
Compound 4: the middle estimate sits 1.8-fold (0.25 log units) above what was measured, and the stated range covers the measured number.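

In this assay, replacing 4-chlorophenyl with 2-fluorobenzyl on the amide-type nitrogen gives an at least 2.9-fold lower number from compound 2 to compound 4 (0.46 log units; beyond the scatter). Within the data shown here, this shows that the group on this nitrogen matters on this core, something the earlier compounds could not show, as their only step concerned a group on a benzyl ring and left the link to that nitrogen as it was. The true size of the new step remains unknown because compound 2 has only a limit, so the step is a floor: the limit of > 100000 nM in this assay, at which 2 of the 4 values shown sit.

This single change replaces a phenyl ring attached directly to the nitrogen with a benzyl group and also swaps chlorine for fluorine, so the compounds shown cannot tell which part of the change counts, or whether the position of the fluorine on the ring plays any role. On these data alone, it also remains open how this nitrogen would respond to quite different groups, such as a benzyl ring carrying an amine or a carboxylic acid, or a longer chain in place of the 2-fluorobenzyl group.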